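From compound 2 to compound 4: an expected clearance step

The source may hold more compounds than are shown below. What is called first, only, known or untested is meant among the compounds shown, and "the series" means these compounds.

Values measured in an ADME assay on microsomes from liver (Homo sapiens) for metabolic stability, read by LC-MS, using NADPH, with stated times of 5 min and 30 min, tested at 1 uM (on this read-out lower numbers stand for slow clearance and higher numbers for fast clearance), are these
Compound 1 `O=C(Nc1ccccc1)c1cnc(NCc2c(F)ccc3c2CCO3)n2cnnc12` gives 14 mL.min-1.g-1
Compound 2 `Cn1cc(-c2cnc(NCc3c(F)ccc4c3CCO4)c3cn[nH]c(=O)c23)cn1` gives 21 mL.min-1.g-1
Compound 3 `Fc1ccc2c(c1CNc1ncc(Oc3ccccc3)c3nncn13)CCO2` gives 18 mL.min-1.g-1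

Compound 2 at 21 mL.min-1.g-1 lies within the scatter of both other compounds, so its number sets no order among the three. Compound 4 `Cc1nc(CN(C)C)ccc1-c1cnc(NCc2c(F)ccc3c2CCO3)c2cn[nH]c(=O)c12` has not yet been measured. The change from compound 2 is 6-((dimethylamino)methyl)-2-methylpyridin-3-yl in place of 1-methyl-1H-pyrazol-4-yl on an aromatic carbon and it places 6-((dimethylamino)methyl)-2-methylpyridin-3-yl in place of 1-methyl-1H-pyrazol-4-yl on an aromatic carbon. Going by the values given here, only one measured step bears on this, and only loosely (a 1.3-fold higher number from compound 1 to compound 3 (0.11 log units; within the scatter)). That step stays within the scatter, and it involves other groups on a core other than that of compound 2. Among the compounds with values here, no measured step involves either group in this change, so the data offer no direction. No shift beyond the scatter is therefore expected (a 1.1-fold higher number from compound 2 to compound 4 (0.06 log units; within the scatter)). In this assay the expected value for compound 4 is 24 mL.min-1.g-1 with an estimated range of 11 mL.min-1.g-1 to 50 mL.min-1.g-1 as its bounds.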

Compound 4, intrinsic clearance in microsomes: 13 mL.min-1.g-1
Beside the measured number, compound 4's estimate is 1.8-fold (0.27 log units) above it; the measured number falls inside the stated range.
By their numbers in this assay, from the lowest: compounds 4, 1, 3 and 2 (each within the scatter of the next).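

In this assay, the change on this aromatic carbon of the shared core gives a 1.6-fold lower number from compound 2 to compound 4 (0.21 log units; within the scatter), the first step shown at this position. The 1-methyl-1H-pyrazol-4-yl group, a five-membered aromatic ring, can thus give way to the 6-((dimethylamino)methyl)-2-methylpyridin-3-yl group, a six-membered aromatic ring with more heavy atoms, and the read-out stays within the scatter. Nothing given here offers an explanation for this step.

From the compounds shown here alone, the new ring, its methyl group and its dimethylaminomethyl group enter together, so their separate shares in the step remain unknown. Going by these compounds, it also remains open whether a morpholine or a carboxylic acid in place of the dimethylamino group would keep the read-out within the scatter of compound 2.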